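The source may report more compounds than this note shows. Statements on the series, on what has been measured and on what is new or still open speak of the compounds shown alone.

Measured compounds:
compound 1 `CC[C@@H](Nc1c(C#N)c(-c2ccc(-c3cnccc3C)cc2)nc2cnccc12)C(N)=O`: 2
compound 2 `CC[C@@H](Nc1c(C#N)c(-c2ccc(-c3cccc(Cl)c3)cc2)nc2cnccc12)C(N)=O`: 3.1

Compound 2 stands highest of the two numbers in a physicochemical assay for lipophilicity, read by HPLC, at pH 7.5; a lower number here means a more polar compound, a higher number a more lipophilic compound; its nearest neighbour is compound 1, whose value sits lower, and the change from compound 1 to compound 2 was a number 1.10 log units higher from compound 1 to compound 2 (beyond the scatter), a large step in this assay. Compound 3 `CC[C@@H](Nc1c(C#N)c(-c2ccc(-c3ccccc3C(C)C)cc2)nc2cnccc12)C(N)=O` has not yet been measured in this assay. It differs from compound 2 in one place: 2-isopropylphenyl in place of 3-chlorophenyl on an aromatic carbon. For the measured compounds named here, the only measured step, a number 1.10 log units higher from compound 1 to compound 2 (beyond the scatter), concerns the same position but swaps different groups, so it guides only loosely; it does show that an exchange at this position can move this assay by a large amount. Compound 3 is therefore expected to lie higher than compound 2, by a number 0.60 log units higher from compound 2 to compound 3 (beyond the scatter), a step beyond the scatter. The estimate for compound 3 is 3.7, with a range from 3.2 to 4.2.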

Compound 3, distribution coefficient: 3.5
Estimate against measurement, compound 3: 0.20 log units above; the range from low to high includes it.
By their numbers in this assay, from the lowest: compound 1; then compound 2; then compound 3.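

In this assay the exchange at this position gives a number 0.40 log units higher from compound 2 to compound 3 (beyond the scatter) and so shows that the number can still rise when the chlorine-bearing phenyl gives way to a phenyl carrying only carbon substituents. Set against compound 1, the change gives a number 1.50 log units higher from compound 1 to compound 3 (beyond the scatter) and is the largest step at this position so far. Both substituted phenyl groups now stand above 4-methylpyridin-3-yl, and none of the three compounds goes against that order. Nothing available here explains the size or direction of these steps.

Since 2-isopropylphenyl differs from 3-chlorophenyl in both the substituent and its place on the ring, the compounds shown cannot separate these two changes. They also leave open where the number would fall with an unsubstituted phenyl, or with an amine or a carboxylic acid on that ring.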